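The source may report more compounds than this note shows. Statements on the series, on what has been measured and on what is new or still open speak of the compounds shown alone.

Compound 1 `Cc1cccc(CN2CCC=C(CCC(=O)NO)C2=O)c1` and compound 2 `O=C(CCC1=CCCN(Cc2ccc(NC(=O)c3ccccc3)cc2)C1=O)NO` have both been measured in a functional assay on HCT-15 cells (Homo sapiens) for inhibition, read by sulforhodamine B assay; a lower number here means a stronger inhibitor of growth, a higher number a weaker inhibitor of growth. Compound 1 gives > 10000 nM, which is a limit of the assay and not a number. Compound 2 gives > 10000 nM, which is also only a limit. Going by the values given here, compound 2 therefore stands at the limit of > 10000 nM in this assay, at which 2 of the 2 values shown sit, and no measured step is available as a guide. Compound 3 `O=C(CCC1=CCCN(Cc2ccc(Br)cc2)C1=O)NO` keeps the core of compound 2 but has bromo in place of benzamido on an aromatic carbon, para to a large group: bromo in place of benzamido on an aromatic carbon. In this assay, no step beyond the usual scatter is expected in either direction, since compound 1 and compound 2 both gave only limits. The estimated step is a step that the limit leaves unreadable from compound 2 to compound 3. For compound 3 the expected value is 14000 nM, with an estimated range from 4000 nM to 40000 nM.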

Compound 3, concentration for 50% growth inhibition: 1720 nM
The estimate for compound 3 lay 8.1-fold (0.91 log units) above the measured number; the whole stated range lies above it.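

Going by these compounds alone, compound 3 is the first compound here to give a real number rather than a limit, which shows that this series can register growth inhibition in this assay. Bromo in place of benzamido, on the aromatic carbon para to a large group, gives an at least 5.8-fold lower number from compound 2 to compound 3 (0.76 log units; beyond the scatter), so the benzamido group is not needed for this activity. A second comparison, 4-bromophenyl in place of 3-methylphenyl, gives an at least 5.8-fold lower number from compound 1 to compound 3 (0.76 log units; beyond the scatter), and both steps are minimum sizes, since each starts from a limit: the limit of > 10000 nM in this assay, at which 2 of the 3 values shown sit.

The step from compound 1 changes both the group and its place on the ring, so a 3-bromophenyl or 4-methylphenyl group would be needed to separate the two. As far as these compounds go, whether a chloro group or an amine at the bromo position would match bromo also stays open.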